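This account rests on a few compounds, and the source may have more. Where it says the series, first, only, none or still open, it means among the compounds named here.

Working notes on the series. The shared core is carried in compound 1 `N#Cc1cnc(NCc2cnccc2C(F)(F)F)cc1N[C@H]1C[C@H](O)C1`, compound 2 `N#Cc1cnc(NCc2cnccc2C(F)(F)F)cc1NC[C@H]1C[C@@H](O)C1` and compound 3 `N#Cc1cnc(NCc2cnccc2C(F)(F)F)cc1NC[C@H]1C[C@H](O)C1`; the three differ only in the group on the nitrogen on the aromatic ring. In an assay on isolated protein for inhibition of protein kinase C theta type (Homo sapiens), read by TR-FRET, with a stated time of 2 h (a higher number here means a weaker inhibitor, a lower number a stronger inhibitor), compound 1 gives 900 nM, compound 2 gives 300 nM and compound 3 gives 700 nM. Compound 2 holds the lowest of the three numbers, with compound 3 nearest and compound 1 furthest. The step of a 3.0-fold lower number from compound 1 to compound 2 (0.48 log units; beyond the scatter) and the step of a 1.3-fold lower number from compound 1 to compound 3 (0.11 log units; within the scatter) show that adding the methylene between ring and nitrogen moves the number by a modest amount at most, and the step of a 2.3-fold higher number from compound 2 to compound 3 (0.37 log units; beyond the scatter) is of similar size; it rests on the fact that (the fact that compounds 2 and 3 differ only in the configuration as drawn).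

Compound 4 `CNC(=O)[C@H]1CC[C@@H](Nc2cc(NCc3cnccc3C(F)(F)F)ncc2C#N)CC1` is the next compound. Its change from compound 2 is 4-(methylcarbamoyl)cyclohexyl in place of (3-hydroxycyclobutyl)methyl on a nitrogen on an aromatic ring. Among the measured compounds shown here, no measured step covers this exchange of ring and substituent, and the only evidence on the series is that single changes at this nitrogen have moved the number by small or modest amounts in either direction. On that basis a modest step in either direction is the most that is expected, and the estimated step is a 1.3-fold higher number from compound 2 to compound 4 (0.12 log units; within the scatter). Compound 4 is therefore expected to give about 400 nM in this assay, within a range from 100 nM to 1500 nM.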

Compound 4, half-maximal inhibitory concentration: 27 nM
The estimate for compound 4 lay 15-fold (1.17 log units) above the measured number; the whole stated range lies above it.
By their numbers in this assay, from the lowest: compound 4; then compound 2; then compounds 3 and 1 (each within the scatter of the next).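

At the nitrogen on the aromatic ring, 4-(methylcarbamoyl)cyclohexyl in place of (3-hydroxycyclobutyl)methyl gives an 11-fold lower number from compound 2 to compound 4 (1.05 log units; beyond the scatter) and a 26-fold lower number from compound 3 to compound 4 (1.41 log units; beyond the scatter), and in place of 3-hydroxycyclobutyl it gives a 33-fold lower number from compound 1 to compound 4 (1.52 log units; beyond the scatter). Among the compounds shown here, these steps show that in this assay this position can move the number much further than the earlier compounds suggested, where the largest step was a 3.0-fold lower number from compound 1 to compound 2 (0.48 log units; beyond the scatter), and they leave compound 4 with the lowest number of the series, beyond the scatter from each of the other three. The exchange alters ring size, substituent and heavy-atom count together, and nothing at hand shows which of these accounts for the gain.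

The compounds shown leave open whether the methylcarbamoyl group is needed, since a 4-hydroxycyclohexyl group or a carboxylic acid on the same cyclohexyl ring would separate the contribution of the ring from that of the amide. Also open, going by these compounds, is whether the configuration of the cyclohexyl ring matters, given that the mirror-image pair gives only a 2.3-fold higher number from compound 2 to compound 3 (0.37 log units; beyond the scatter).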